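Vinyl in place of propyl on the ring of compound 1

This account rests on a few compounds, and the source may have more. Where it says the series, first, only, none or still open, it means among the compounds named here.

Going by the values given here, compound 1 `CCCc1csc(CN[C@@H]2C[C@H]3C[C@@H]([C@H]2C)C3(C)C)c1` is the only compound of the series with a number in an ADME assay on MDCK cells (Canis lupus familiaris) for cytotoxicity, read by microscopy, with a stated time of 48 h (on this read-out higher numbers stand for lower toxicity in this test and lower numbers for higher toxicity in this test), where compound 1 gives 12500 nM. Compound 2 `C[C@H]1[C@H](NCc2cncs2)C[C@H]2C[C@@H]1C2(C)C` reaches only the assay limit, > 100000 nM. Compound 3 `Cc1csc(CN[C@@H]2C[C@H]3C[C@@H]([C@H]2C)C3(C)C)n1` likewise stops at the limit, > 100000 nM. Among the compounds with values here, the single step between measured compounds, a step that the two limits leave unreadable from compound 2 to compound 3, is thus unreadable, and the series is dominated by the limit of > 100000 nM in this assay, at which 2 of the 3 values shown sit. Compound 4 `C=Cc1csc(CN[C@@H]2C[C@H]3C[C@@H]([C@H]2C)C3(C)C)c1` differs from compound 1 by vinyl in place of propyl on an aromatic carbon. Within the data shown here, no measured step touches this position, so nothing in the data argues for a shift beyond scatter in this assay in either direction. The expected step is no change at the digits printed from compound 1 to compound 4 (within the scatter). Compound 4 is therefore estimated at 12500 nM, between 4000 nM and 50000 nM.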

Compound 4, minimum cytotoxic concentration: 6250 nM
Estimate against measurement, compound 4: 2.0-fold (0.30 log units) above; the measured number falls inside the stated range.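

The position two ring bonds from the ring sulfur now has its first measured step in this assay, which is a 2.0-fold lower number from compound 1 to compound 4 (0.30 log units; within the scatter). Vinyl in place of propyl, which brings one double bond outside aromatic rings, therefore stays within the scatter, and compound 4 gives the series a second number alongside compound 1. The other compounds shown still stop at a limit: the limit of > 100000 nM in this assay, at which 2 of the 4 values shown sit.

On these data alone, whether an amine, a carboxylic acid or a longer chain at this position would move the number beyond the scatter remains open.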